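Amide variation on the shared core

This account rests on a few compounds, and the source may have more. Where it says the series, first, only, none or still open, it means among the compounds named here.

Compound 1 `COc1cc2ncnc(Nc3ccc(NC(=O)c4ccc(C)cc4)cc3)c2cc1OC` and compound 2 `COc1cc2ncnc(Nc3ccc(NC(=O)c4ccccc4Cl)cc3)c2cc1OC` share the core and differ only in the group on the carbonyl carbon. In a functional assay on MCF7 cells (Homo sapiens) for inhibition, read by MTT assay (a higher number here means a weaker inhibitor, a lower number a stronger inhibitor), compound 1 gives 19000 nM, and compound 2 gives 36000 nM. For the measured compounds named here, compound 2 carries the highest of the two numbers measured so far, but the step of a 1.9-fold higher number from compound 1 to compound 2 (0.28 log units; within the scatter) lies within the scatter, so the two compounds cannot be ordered. Compound 3 `COc1cc2ncnc(Nc3ccc(NC(=O)c4ccc(Cl)c(Cl)c4)cc3)c2cc1OC` is the next member, not yet measured in this assay. Its change from compound 2 is 3,4-dichlorophenyl in place of 2-chlorophenyl on a carbonyl carbon. Going by the values given here, the only step that bears on this position is a 1.9-fold higher number from compound 1 to compound 2 (0.28 log units; within the scatter), which exchanged one group on the carbonyl carbon for another without moving the number beyond the scatter. A step of similar size is therefore expected here, a 1.2-fold lower number from compound 2 to compound 3 (0.08 log units; within the scatter), with no direction supported by the two numbers available. For compound 3 the expected value in this assay is 30000 nM, with a range from 10000 nM to 90000 nM.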

Compound 3, half-maximal inhibitory concentration: 25000 nM
Beside the measured number, compound 3's estimate is 1.2-fold (0.08 log units) above it; the range from low to high includes it.
By their numbers in this assay, from the lowest: compounds 1, 3 and 2 (each within the scatter of the next).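

In this assay, there is a 1.4-fold lower number from compound 2 to compound 3 (0.16 log units; within the scatter) and a 1.3-fold higher number from compound 1 to compound 3 (0.12 log units; within the scatter), so the three groups on the carbonyl carbon cannot be ordered. Going from 1 chlorine in 2-chlorophenyl to 2 chlorine in 3,4-dichlorophenyl gives no readable change, and 3,4-dichlorophenyl is no more separable from 4-methylphenyl than 2-chlorophenyl was, so all three exchanges at this place stay within the scatter. No available measurement explains this flat result.

On these data alone, all three compounds carry a phenyl group bearing only chlorine or methyl, so it remains open whether an amine or a carboxylic acid on that ring, or a longer chain in place of it, would move the number beyond the scatter. As far as these compounds go, the shared core is constant throughout, and the effect of changes to it also remains open.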